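The source may hold more compounds than are shown below. What is called first, only, known or untested is meant among the compounds shown, and "the series" means these compounds.

Compound 1, `O=[N+]([O-])c1ccc(N2CCCN(CCC(O)c3csc4ccccc34)CC2)c(C(F)(F)F)c1`: 8710 nM in an assay on HEK293 cells for displacement of a labelled ligand from 5-hydroxytryptamine receptor 7 (Homo sapiens), read by scintillation counting, with a stated time of 1 h; a higher number here means a weaker inhibitor, a lower number a stronger inhibitor.
Compound 2, `N#Cc1ccc(N2CCCN(CCC(=O)c3csc4ccccc34)CC2)cc1`: 15100 nM in this assay.

In this assay compound 2 gives 15100 nM, and the number for compound 1, 8710 nM, lies within the usual scatter of it, so the two are not told apart. Compound 3 `O=C(CCN1CCCN(c2cnc3ccccc3n2)CC1)c1csc2ccccc12` remains unmeasured; it differs from compound 2 by quinoxalin-2-yl in place of 4-cyanophenyl on an amine nitrogen in a ring. Among the compounds with values here, no measured pair shows this change, so its direction in this assay is not known from these data. The step is expected to be modest, estimated as a 3.0-fold lower number from compound 2 to compound 3 (0.48 log units; beyond the scatter), toward a somewhat lower number. Compound 3 is estimated to give 5000 nM, with a range of 1000 nM to 25000 nM.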

Compound 3, inhibition constant: 9550 nM
For compound 3 the middle estimate is 1.9-fold (0.28 log units) below the measured one; low and high end bracket the measured number.
By their numbers in this assay, from the lowest: compounds 1, 3 and 2 (each within the scatter of the next).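

At the amine nitrogen in the seven-membered ring, quinoxalin-2-yl in place of 4-cyanophenyl gives, in this assay, a 1.6-fold lower number from compound 2 to compound 3 (0.20 log units; within the scatter). Within the data shown here, this is the first reading at this position, and it does not tell the two groups apart: losing the nitrile and gaining a second aromatic ring, one with hetero atoms, leaves the number within the scatter. Nothing here gives a reason for this result. From the compounds shown here alone, whether a benzyl group or a small alkyl chain on this nitrogen would move the number beyond the scatter remains open.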